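This account rests on a few compounds, and the source may have more. Where it says the series, first, only, none or still open, it means among the compounds named here.

Measured so far:
- compound 1, `CON1C[C@@H](NC(=O)OCCCCC2CCCCC2)C1=O`: 56 nM
- compound 2, `C[C@H]1[C@H](NC(=O)OCCCCC2CCCCC2)C(=O)N1OCCCCC1CCCCC1`: 3470 nM

Both compounds were tested in an assay on HEK293 cells for inhibition of N-acylethanolamine-hydrolyzing acid amidase (Homo sapiens), read by fluorescence, with stated times of 10 min and 50 min; a higher number here means a weaker inhibitor, a lower number a stronger inhibitor. Compound 1 gives 56 nM, the lower of the two numbers. Compound 2 gives 3470 nM, the highest number seen here, so on these two values compound 2 is the weaker inhibitor, and the gap between compound 1 and compound 2 lies well beyond the usual scatter of repeated measurements.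

Compound 3, `C[C@H]1[C@H](NC(=O)OCCCCC2CCCCC2)C(=O)N1Oc1ccc(S(C)(=O)=O)cc1`, has not yet been tested in this assay. It differs from compound 2 at one place:

4-(methylsulfonyl)phenyl in place of 4-cyclohexylbutyl on an oxygen

Among the measured compounds shown here, no pair of measured compounds shows this kind of change, so there is no measured step to lean on. The expectation can rest only on the fact that compound 2 gives 3470 nM and on the nature of the exchange. Compound 3 is expected to give 800 nM, with a likely range from 150 nM to 5000 nM. The step of a 4.3-fold lower number from compound 2 to compound 3 (0.64 log units; beyond the scatter) is thus estimated as a move toward a stronger inhibitor, though the wide range leaves room for no step beyond the scatter.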

Compound 3, half-maximal inhibitory concentration: 6 nM
Beside the measured number, compound 3's estimate is 130-fold (2.12 log units) above it; measured number outside the range, below it.
By their numbers in this assay, from the lowest: compound 3; then compound 1; then compound 2.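

In this assay, the group on the oxygen whose other neighbour is the amide-type nitrogen in a ring has a strong influence on the result: putting 4-(methylsulfonyl)phenyl in place of 4-cyclohexylbutyl gives a 580-fold lower number from compound 2 to compound 3 (2.76 log units; beyond the scatter), a large change. The two groups have the same number of heavy atoms, so this step does not come with any change in that count; what differs is that an aromatic ring replaces a non-aromatic one, and the entering group brings hydrogen-bond acceptors that the leaving group lacks. No measurement here shows which of these differences accounts for the step.

The single exchange changes the ring and the methylsulfonyl group together, so the compounds shown leave open how much of the step belongs to each. A plain phenyl group on the same oxygen would begin to separate the two, and a phenyl ring carrying a nitrile or a carboxylic acid in place of the methylsulfonyl group would show whether the gain depends on that particular group.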